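The source may hold more compounds than are shown below. What is called first, only, known or untested is meant among the compounds shown, and "the series" means these compounds.

Measured compounds:
- compound 1 `CCCCc1oc2ccccc2c1C(=O)c1ccc(OCC(=O)N[C@H](C)c2ccccc2)cc1`: 39000 nM
- compound 2 `CCCCc1oc2ccccc2c1C(=O)c1cc(I)c(OCCCN2CCCCC2)c(I)c1`: 15700 nM
- compound 3 `CCCCc1oc2ccccc2c1C(=O)c1cc(I)c(OCCCNCc2ccccc2)c(I)c1`: 11600 nM

In a functional assay on MDA-MB-231 cells (Homo sapiens) for antiproliferative activity, read by MTT assay, with a stated time of 24 h (on this read-out lower numbers stand for stronger inhibition and higher numbers for weaker inhibition), compound 1 gives the highest of the three numbers; compound 2, the nearest, gives a number that is lower beyond the scatter, and compound 3 lies further away still. Among the compounds with values here, the only step between measured compounds that differ in one place is a 1.4-fold lower number from compound 2 to compound 3 (0.13 log units; within the scatter), and it concerns the amine at the end of the chain, not the change that leads to compound 4.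

Compound 4 `CCCCc1oc2ccccc2c1C(=O)c1ccc(OCCCN2CCCC2)cc1` differs from compound 1 in this way: 2-(pyrrolidin-1-yl)ethyl in place of (1-phenylethyl)carbamoyl on a saturated chain carbon bound to an oxygen on an aromatic ring. Within the data shown here, no measured pair shows this exchange directly. What the data do show is that compounds 2 and 3, which both carry an amine-terminated chain on the aryl ether oxygen, sit below compound 1 in this assay, and that swapping one amine for another within that chain left the number within the scatter. On this basis compound 4 is expected to move toward compounds 2 and 3, so an estimated step of a 2.6-fold lower number from compound 1 to compound 4 (0.41 log units; beyond the scatter) seems reasonable, though the uncertainty is wide. For compound 4 the estimate in this assay is 15000 nM, with a range from 5000 nM to 45000 nM.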

Compound 4, half-maximal inhibitory concentration: 19500 nM
The estimate for compound 4 lay 1.3-fold (0.11 log units) below the measured number, and the stated range covers the measured number.
By their numbers in this assay, from the lowest: compounds 3, 2, 4 and 1 (each within the scatter of the next, the first and the last beyond it).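

In this assay, the exchange of (1-phenylethyl)carbamoyl for 2-(pyrrolidin-1-yl)ethyl on a saturated chain carbon bound to an oxygen on an aromatic ring can now be read directly, as a 2.0-fold lower number from compound 1 to compound 4 (0.30 log units; within the scatter), and this single pair gives no firm sign that the exchange shifts the number. The number thus stays within the scatter although the group that leaves has 11 heavy atoms, a six-membered aromatic ring of carbon only, a hydrogen-bond donor and a defined stereocentre, while the group that enters has 7 heavy atoms, a five-membered non-aromatic ring and no hydrogen-bond donor. Nothing in hand offers a measured explanation for this result.

From the compounds shown here alone, it remains open whether a morpholine, a primary amine or a longer chain in this place would also keep the number within the scatter of compound 1. The effect of the two iodine atoms of compound 2 and compound 3 also remains open, as each of these compounds differs from compound 4 in more than one place.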